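A few compounds are considered here, and "the series" means these few. Any claim that something is new, unique, unknown or untested is made for them only; others in the source may bear on it.

Measured compounds:
Compound 1, `CC(C)(C)c1ccccc1Oc1ncccc1NC(=O)Nc1ccc(-c2ccccc2CO)cc1F`, gives 54 nM in an assay on isolated protein for binding affinity to P2Y purinoceptor 1 (Homo sapiens); a lower number here means a stronger inhibitor, a higher number a weaker inhibitor.
Compound 2, `CN(C)Cc1ccc(NC(=O)Nc2cccnc2Oc2ccccc2C(C)(C)C)c(F)c1`, gives 322 nM in this assay.

Among the measured compounds shown here, of the two numbers, compound 2 carries the higher one, and the only neighbour is compound 1, whose step to it is a 6.0-fold higher number from compound 1 to compound 2 (0.78 log units; beyond the scatter). That step swapped the 2-(hydroxymethyl)phenyl group for a (dimethylamino)methyl group and cost a clear amount of binding.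

Compound 3, `CN(C)Cc1cccc(-c2ccc(NC(=O)Nc3cccnc3Oc3ccccc3C(C)(C)C)c(F)c2)c1`, has not been measured. It differs from compound 2 in one place: 3-((dimethylamino)methyl)phenyl in place of (dimethylamino)methyl on an aromatic carbon. The change thus puts a phenyl ring back at the spot where compound 1 carried one, while keeping the (dimethylamino)methyl group, now attached to that ring. For the measured compounds named here, the single step that bears on this, from compound 1 to compound 2, shows the aromatic ring at this position to be worth a modest but real gain. It is therefore reasonable to expect a step back down toward compound 1, though the different substituent on the ring leaves the size uncertain. Compound 3 is expected to give 100 nM, within 35 nM to 300 nM. The estimated step is a 3.2-fold lower number from compound 2 to compound 3 (0.51 log units; beyond the scatter).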

Compound 3, inhibition constant in the P2Y purinoceptor 1 assay: 34 nM
Estimate against measurement, compound 3: 2.9-fold (0.47 log units) above; measured number below the stated range.
By their numbers in the P2Y purinoceptor 1 assay, from the lowest: compounds 3 and 1 (each within the scatter of the next); then compound 2.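

Carrying the (dimethylamino)methyl group on a phenyl ring, as the 3-((dimethylamino)methyl)phenyl group, restores the binding lost in compound 2, and in the P2Y purinoceptor 1 assay the result is a 9.5-fold lower number from compound 2 to compound 3 (0.98 log units; beyond the scatter). Set against compound 1, the replacement of 2-(hydroxymethyl)phenyl by 3-((dimethylamino)methyl)phenyl gives in the P2Y purinoceptor 1 assay a 1.6-fold lower number from compound 1 to compound 3 (0.20 log units; within the scatter), so across these compounds the aromatic ring matters more at this position than which of the two substituents it carries or where that substituent sits on it. In a physicochemical assay for solubility, in phosphate buffer, at pH 6.5 (on this read-out lower numbers stand for lower solubility and higher numbers for higher solubility), compound 2 gives 160 ug/mL and compound 3 gives 17 ug/mL. The added ring also has a price that the earlier compounds could not show, seen in the physicochemical assay: the measured solubility of compound 2, 160 ug/mL, and of compound 3, 17 ug/mL, a 9.4-fold lower number (0.97 log units; beyond the scatter)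

On these data alone, how much of the binding belongs to the phenyl ring alone and how much to the group it carries remains open, and an unsubstituted phenyl ring or one bearing a carboxylic acid would separate the two. As far as these compounds go, it is also open whether a morpholine on that ring, in place of the dimethylamino group, would keep the binding of compound 3 while giving back some of the solubility of compound 2.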